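Shrinking a Ring on an Aromatic Nitrogen

The compounds below may be only part of what the source reports. "The series", "measured", "known", "first", "only" and "open" are said of these compounds alone.

Among the measured compounds shown here, in a functional assay on RAW264.7 cells (Mus musculus) for inhibition, read by Griess assay, with stated times of 2 h and 24 h (a higher number here means a weaker inhibitor, a lower number a stronger inhibitor), compound 2 `COc1ccc([C@@H]2CC(=O)c3c(O)cc(OCc4cn(C5CCCC5)nn4)cc3O2)cc1O` gives 10500 nM and stands lowest of the two numbers measured so far. Its nearest neighbour is compound 1 `COc1ccc([C@@H]2CC(=O)c3c(O)cc(OCc4cn(Cc5ccc(C(F)(F)F)cc5)nn4)cc3O2)cc1O` which in this assay gives 17700 nM and lies within the scatter of compound 2. For the measured compounds named here, the single step between measured compounds, a 1.7-fold lower number from compound 1 to compound 2 (0.23 log units; within the scatter) came from putting cyclopentyl in place of 4-(trifluoromethyl)benzyl on an aromatic nitrogen. Compound 3 `COc1ccc([C@@H]2CC(=O)c3c(O)cc(OCc4cn(C5CCC5)nn4)cc3O2)cc1O` differs from compound 2 by cyclobutyl in place of cyclopentyl on an aromatic nitrogen at the same place. This exchange is smaller than the one already measured, and since the larger exchange moved the number by only a 1.7-fold lower number from compound 1 to compound 2 (0.23 log units; within the scatter) no step beyond the scatter is expected here. The expected step is no change at the digits printed from compound 2 to compound 3 (within the scatter) in this assay. Compound 3 is therefore estimated to give about 10500 nM with a range from 5000 nM to 22000 nM in this assay.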

Compound 3, half-maximal inhibitory concentration: 15300 nM
The estimate for compound 3 lay 1.5-fold (0.16 log units) below the measured number, within the range that was stated.
By their numbers in this assay, from the lowest: compounds 2, 3 and 1 (each within the scatter of the next).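

In this assay, the step of a 1.5-fold higher number from compound 2 to compound 3 (0.16 log units; within the scatter) comes from cyclobutyl in place of cyclopentyl, and the step of a 1.2-fold lower number from compound 1 to compound 3 (0.06 log units; within the scatter) comes from cyclobutyl in place of 4-(trifluoromethyl)benzyl. With a third group on this aromatic nitrogen, all three compounds now lie within the scatter of one another, so this assay does not separate the four-membered ring from the five-membered ring, nor either ring from the 4-(trifluoromethyl)benzyl group. Nothing available explains these numbers.

The compounds shown leave open whether any group on this nitrogen gives a step beyond the scatter. A methyl group, a longer chain, or a chain ending in an amine or a carboxylic acid could each test this, and the three carbon-based groups here cannot answer it.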